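A few compounds are considered here, and "the series" means these few. Any claim that something is new, unique, unknown or untested is made for them only; others in the source may bear on it.

Among the three compounds measured in an assay on MDA-MB-231 cells for binding affinity to C-X-C chemokine receptor type 4 (Homo sapiens), read by immunofluorescence and microscopy, with stated times of 10 min and 30 min (a higher number here means that more compound is needed for the effect, a lower number that less compound is needed), compound 3 `COc1ccccc1C(=O)NCc1ccc(CNS(=O)(=O)c2ccccc2)cc1` stands lowest, at 1 nM. Compound 1 `O=C(NCc1ccc(CNS(=O)(=O)c2ccccc2)cc1)c1ccccc1Cl` gives 10 nM in this assay, and compound 2 `Cc1ccc(S(=O)(=O)NCc2ccc(CNC(=O)c3cccc(Cl)c3)cc2)cc1` gives 100 nM, so compound 3 lies well apart from both. Going by the values given here, the only single-point step within the set is a 10-fold lower number from compound 1 to compound 3 (1.00 log units; beyond the scatter), which is modest in size.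

Compound 4 `O=C(NCc1ccc(CNS(=O)(=O)c2ccccc2)cc1)c1cccc(Cl)c1` differs from compound 3 in one place: 3-chlorophenyl in place of 2-methoxyphenyl on a carbonyl carbon. Two pieces of evidence bear on this. First, the step from compound 1 to compound 3 runs in the opposite direction to what is now done, since a methoxy-bearing ring is again exchanged for a chloro-bearing one; read backwards, it points toward a higher number of roughly the same size. Second, compound 2 also carries a 3-chlorophenyl on the carbonyl carbon and gives 100 nM, although it differs from compound 4 elsewhere and no step between them has been measured. On that basis a step upward, clearly beyond the scatter, is expected. Compound 4 is therefore expected to give about 30 nM in this assay, within a range from 8 nM to 150 nM. The expected step from compound 3 to compound 4 is a 30-fold higher number from compound 3 to compound 4 (1.48 log units; beyond the scatter).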

Compound 4, effective concentration (reported as EC, without a stated level of effect): 1000 nM
Estimate against measurement, compound 4: 33-fold (1.52 log units) below, and the stated range ends below it.
By their numbers in this assay, from the lowest: compound 3; then compound 1; then compound 2; then compound 4.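

In this assay, going by these compounds alone, the substituted phenyl on the carbonyl carbon proves far more decisive than the earlier compounds could show: 3-chlorophenyl in place of 2-methoxyphenyl gives a 1000-fold higher number from compound 3 to compound 4 (3.00 log units; beyond the scatter), and 3-chlorophenyl in place of 2-chlorophenyl alone gives a 100-fold higher number from compound 1 to compound 4 (2.00 log units; beyond the scatter), so which chlorophenyl stands there matters even with the rest of the molecule unchanged. The 3-chlorophenyl does not fix the number by itself, as hydrogen in place of methyl on an aromatic carbon, with that group kept, gives a 10-fold higher number from compound 2 to compound 4 (1.00 log units; beyond the scatter), so a change elsewhere in the molecule also moves the result beyond the scatter. Nothing at hand explains why these changes have such an effect.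

The compounds shown leave open whether the same methyl would raise or lower the number when the carbonyl carbon bears 2-methoxyphenyl or 2-chlorophenyl instead of 3-chlorophenyl. They also leave open how this position would respond to other groups on the phenyl ring, such as an amine, a carboxylic acid, an ethoxy group or a fluorine atom.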